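A Nitro Group Tried Twice Across Two Related Cores

The compounds below may be only part of what the source reports. "The series", "measured", "known", "first", "only" and "open" are said of these compounds alone.

In a functional assay on KB cells (Homo sapiens) for antiproliferative activity, read by MTT assay, with a stated time of 72 h (a lower number here means a stronger inhibitor, a higher number a weaker inhibitor), compound 1 `COc1ccc(-c2sccc2-c2cc(OC)c(OC)c(OC)c2)cc1` gives 8880 nM. Compound 2 `COc1ccc(-c2sccc2-c2cc(OC)c(OC)c(OC)c2)cc1[N+](=O)[O-]` differs from compound 1 in one place, (nitro in place of hydrogen on an aromatic carbon), and in this assay compound 2 gives 10600 nM; the change made a 1.2-fold higher number from compound 1 to compound 2 (0.08 log units; within the scatter). Compound 3 `COc1ccc(-c2cc(C(=O)O)sc2-c2cc(OC)c(OC)c(OC)c2)cc1` has a different core from compound 1, and the difference between the two cores is not broken down here. In this assay compound 3 gives 8650 nM. Compound 4 `COc1ccc(-c2cc(C(=O)O)sc2-c2cc(OC)c(OC)c(OC)c2)cc1[N+](=O)[O-]` carries the same change on the core of compound 3, (nitro in place of hydrogen on an aromatic carbon), and the surroundings of the place are described in the same words, so it is the same change. Because the earlier step was a 1.2-fold higher number from compound 1 to compound 2 (0.08 log units; within the scatter), a step of about that size is expected from compound 3 to compound 4, namely a 1.2-fold higher number from compound 3 to compound 4 (0.06 log units; within the scatter). Compound 4 is therefore estimated at 10000 nM, expected to fall between 5000 nM and 20000 nM.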

Compound 4, half-maximal inhibitory concentration: 43700 nM
Beside the measured number, compound 4's estimate is 4.4-fold (0.64 log units) below it; measured number outside the range, above it.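

In this assay, putting the nitro group in place of hydrogen on the second core gave a 5.1-fold higher number from compound 3 to compound 4 (0.70 log units; beyond the scatter), so the change did not carry over at the size it had on the core of compound 1. The two steps differ: the same change on two cores in this assay, a 1.2-fold higher number (0.08 log units; within the scatter) from compound 1 to compound 2 and a 5.1-fold higher number (0.70 log units; beyond the scatter) from compound 3 to compound 4, 4.2-fold (0.63 log units) apart, beyond the scatter of two such steps. This shows that the size of this step cannot simply be transferred between these two cores, but a single pair on each core does not show which difference between the cores matters or how a further core would respond.

On these data alone, it remains open whether the carboxylic acid of compound 3 goes with the larger step, which a methyl ester in its place could test. Also open, as far as these compounds go, is how an amine would behave in the place taken by the nitro group.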